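Mirrored Stereocentres and Vero Cell Tolerance

A few compounds are considered here, and "the series" means these few. Any claim that something is new, unique, unknown or untested is made for them only; others in the source may bear on it.

Measured so far in a functional assay on Vero cells (Chlorocebus sabaeus) for cytotoxicity (a higher number here means that more compound is tolerated, a lower number that less compound is tolerated), are two compounds
- compound 1 (`O=c1[nH]c(=O)n([C@H]2CO[C@H](CO)O2)cc1/C=C/Br`) with 100 ug/mL
- compound 2 (`O=c1[nH]c(=O)n([C@H]2CO[C@@H](CO)S2)cc1/C=C/Br`) with 100 ug/mL

On these numbers compound 2 stands level with compound 1, within the usual scatter. Compound 3 (`O=c1[nH]c(=O)n([C@@H]2CO[C@H](CO)S2)cc1/C=C/Br`) has the same atoms and bonds as compound 2 and differs only in configuration as drawn (the two compounds have the same atoms and bonds and differ only in configuration as drawn: 2 of 3 stereo elements differ; a stereocentre at a saturated ring carbon is drawn R in compound 2 and S in compound 3; a stereocentre at a saturated ring carbon is drawn R in compound 2 and S in compound 3). Among the compounds with values here, no measured pair shows what such a change does here. Within the data shown here, compound 1 at 100 ug/mL and compound 2 at 100 ug/mL are the only guides. The expected step in this assay is nothing beyond the scatter, in either direction (no change at the digits printed from compound 2 to compound 3 (within the scatter)). Compound 3 is estimated at 100 ug/mL with an expected range from 50 ug/mL to 200 ug/mL for its measurement.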

Compound 3, half-maximal cytotoxic concentration: > 100 ug/mL
Compound 3 was reported as a limit; the forecaster's own chance of this, stated with the estimate: 30%; the middle value sits exactly at the limit.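

Changing the configuration at two saturated ring carbons, with atoms and bonds untouched, gives a number no lower from compound 2 to compound 3 (the limit leaves the size open) in this assay. Compound 3 gives > 100 ug/mL, which is a limit and not a number. This mirroring therefore leaves the compound no less tolerated, but the size of the step cannot be read: the limit of > 100 ug/mL in this assay, at which 1 of the 3 values shown sits.

Still open, as far as these compounds go, is whether the same change in configuration would act alike in compound 1. Also open, from the compounds shown here alone, is what an amine or a carboxylic acid in place of the hydroxymethyl group would do to tolerance.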